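The compounds below may be only part of what the source reports. "The series", "measured", "known", "first", "only" and "open" are said of these compounds alone.

Within the data shown here, compound 1 `O=C1[C@@H](NS(=O)(=O)c2ccc(-c3ccccn3)s2)CCN1Cc1cc2cc[nH]cc-2n1` is one of two compounds measured in an assay on isolated protein for inhibition of coagulation factor X (Oryctolagus cuniculus), tested at 1 uM; on this read-out lower numbers stand for less inhibition and higher numbers for more inhibition at the one concentration tested (going by the name of the read-out); in this assay compound 1 gives 17%, the lower of the two numbers, and its only neighbour, compound 2 `O=C1[C@@H](NS(=O)(=O)c2ccc(-c3ccncc3)s2)CCN1Cc1cc2cc[nH]cc-2n1`, gives 50%. Among the measured compounds shown here, the one measured step, a number 33 percentage points higher from compound 1 to compound 2 (beyond the scatter), comes from pyridin-4-yl in place of pyridin-2-yl on an aromatic carbon.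

Compound 3 `O=C1[C@@H](NS(=O)(=O)c2ccc(-c3ccccn3)s2)CCN1CCNc1ccncc1` has not been measured. It differs from compound 1 as follows: a group of 8 heavy atoms (6 carbon, 2 nitrogen; one six-membered aromatic ring with 1 hetero atom) in place of a group of 9 heavy atoms (7 carbon, 2 nitrogen; one five-membered aromatic ring with 1 hetero atom, one six-membered aromatic ring with 1 hetero atom), on a saturated chain carbon bound to an amide-type nitrogen in a ring. For the measured compounds named here, this change sits on a saturated chain carbon bound to an amide-type nitrogen in a ring, a place untouched by the step from compound 1 to compound 2, so that step does not bear on it, and no measured step does. Compound 1 already stands low, so compound 3 is expected to give a number near it, with a step of a number 2 percentage points lower from compound 1 to compound 3 (within the scatter) expected that may stay within the scatter. The estimate for compound 3 is 15%, between 0% and 45%.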

Compound 3, a percentage reported as inhibition, at one concentration (the size of the read-out at that concentration, not a potency): 18%
Compound 3: the middle estimate sits 3 percentage points below what was measured, within the range that was stated.
By their numbers in this assay, from the lowest: compounds 1 and 3 (each within the scatter of the next); then compound 2.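

At the saturated chain carbon bound to an amide-type nitrogen in a ring, ((pyridin-4-yl)amino)methyl in place of the group with a five-membered and a six-membered aromatic ring gives a number 1 percentage points higher from compound 1 to compound 3 (within the scatter) in this assay, so the two compounds cannot be told apart. Among these compounds, the first measured change at this place thus shows that, with pyridin-2-yl kept on the aromatic carbon, the five-membered ring is not required for a number of this size. Nothing available explains this result.

As far as these compounds go, it remains open whether the two groups would also match with pyridin-4-yl in place of pyridin-2-yl, the change that gave the higher number in compound 2. From the compounds shown here alone, how a plain amine, a carboxylic acid or a longer chain at this place would read also remains open.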